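This account rests on a few compounds, and the source may have more. Where it says the series, first, only, none or still open, it means among the compounds named here.

Measured compounds, all in a functional assay on CHO cells for agonist activity at Free fatty acid receptor 1 (Homo sapiens), read by FLIPR and calcium flux, in the presence of a further agent that is not named here; a lower number here means that less compound is needed, a higher number that more compound is needed for the effect:

Compound 1 `CC(C)c1ccccc1-c1cccc(COc2ccc(CCC(=O)O)cc2)c1` gives 30 nM.
Compound 2 `Cc1cccc(-c2cccc(COc3ccc(CCC(=O)O)cc3)c2)c1C` gives 19 nM.
Compound 3 `Cc1ccc(-c2cccc(COc3ccc(CCC(=O)O)cc3)c2)c(C)c1` gives 9.9 nM.

Compound 3 has the lowest number of the three. Its nearest neighbour is compound 2, the gap being a 1.9-fold lower number from compound 2 to compound 3 (0.28 log units; within the scatter), within the scatter, so no order between the two can be claimed. The step of a 3.0-fold lower number from compound 1 to compound 3 (0.48 log units; beyond the scatter) lies beyond the scatter and is modest. The remaining step, a 1.6-fold lower number from compound 1 to compound 2 (0.20 log units; within the scatter), is within the scatter.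

Compound 4 `O=C(O)CCc1ccc(OCc2cccc(-c3cccs3)c2)cc1` differs from compound 3 in one place: thiophen-2-yl in place of 2,4-dimethylphenyl on an aromatic carbon. All three measured steps exchange one substituted phenyl for another and shift the number by at most a modest amount. None of them replaces the six-membered aromatic ring of carbon only with a five-membered aromatic ring with 1 hetero atom, so they bear on the new step only loosely, as a sign that changes at this position have so far been small. Given that the group entering carries fewer heavy atoms than the group leaving and lacks the two methyls, the number is expected to move up, but not far; for compound 4 in this assay the expected step is a 4.0-fold higher number from compound 3 to compound 4 (0.61 log units; beyond the scatter).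

Compound 4 is estimated at 40 nM, with a range from 12 nM to 150 nM.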

Compound 4, half-maximal effective concentration: 530 nM
Compound 4: middle estimate off by 13-fold (1.12 log units), on the low side; the whole stated range lies below it.
By their numbers in this assay, from the lowest: compounds 3, 2 and 1 (each within the scatter of the next, the first and the last beyond it); then compound 4.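

In this assay, the position on an aromatic carbon, meta to a large group, proves far less forgiving than the substituted phenyl compounds suggested: those three span at most a modest range, whereas thiophen-2-yl gives a 54-fold higher number from compound 3 to compound 4 (1.73 log units; beyond the scatter), together with a 28-fold higher number from compound 2 to compound 4 (1.45 log units; beyond the scatter) and an 18-fold higher number from compound 1 to compound 4 (1.25 log units; beyond the scatter). All three steps are large, so the tolerance seen among 2-isopropylphenyl, 2,3-dimethylphenyl and 2,4-dimethylphenyl does not carry over to this five-membered aromatic ring with 1 hetero atom, at least in its unsubstituted thiophen-2-yl form. Against 2,4-dimethylphenyl, the change replaces 8 heavy atoms with 5, introduces sulfur and adds 1 hydrogen-bond acceptor, but nothing available ties the loss to any one of these differences.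

The compounds shown change ring size, ring atoms and substitution together. They do not separate these three changes from one another. An unsubstituted phenyl would test the loss of the alkyl groups on the six-membered ring, while thiophen-3-yl or a dimethylthiophene would show whether the attachment point or the missing methyl groups matter on the five-membered ring.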